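Removing the methyl from compound 2

A few compounds are considered here, and "the series" means these few. Any claim that something is new, unique, unknown or untested is made for them only; others in the source may bear on it.

In a functional assay on HeLa cells (Homo sapiens) for antiproliferative activity, with a stated time of 5 days (a higher number here means a weaker inhibitor, a lower number a stronger inhibitor), compound 1 `O=C1C=CC2(C=C1)OCC(=O)N2c1nc(-c2ccc3ncccc3c2)nn1-c1ccccc1` gives 110 nM and compound 2 `Cc1ccc(-n2nc(-c3cccc4ccccc34)nc2N2C(=O)COC23C=CC(=O)C=C3)cc1` gives 140 nM, so compound 2 stands within the scatter of compound 1. Compound 3 `O=C1C=CC2(C=C1)OCC(=O)N2c1nc(-c2cccc3ccccc23)nn1-c1ccccc1` differs from compound 2 in one place: hydrogen in place of methyl on an aromatic carbon. This is hydrogen in place of methyl on an aromatic carbon, taking 4-methylphenyl to phenyl. For the measured compounds named here, no measured pair isolates this change, so no step beyond the scatter is expected, in either direction. The expected step is a 1.1-fold lower number from compound 2 to compound 3 (0.03 log units; within the scatter). For compound 3, the estimated value is 130 nM, with an expected range of 60 nM to 280 nM.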

Compound 3, half-maximal inhibitory concentration: 70 nM
The estimate for compound 3 lay 1.9-fold (0.27 log units) above the measured number, and the stated range covers the measured number.
By their numbers in this assay, from the lowest: compounds 3, 1 and 2 (each within the scatter of the next).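

In this assay the 4-methylphenyl to phenyl change gives a 2.0-fold lower number from compound 2 to compound 3 (0.30 log units; within the scatter) and so shows no effect of this methyl beyond the scatter, with the naphthalen-1-yl group held fixed. With phenyl held fixed, naphthalen-1-yl in place of quinolin-6-yl gives a 1.6-fold lower number from compound 1 to compound 3 (0.20 log units; within the scatter) and likewise stays inside the scatter. No supporting evidence bears on either step. The compounds shown carry only methyl or hydrogen on this aromatic carbon, so it remains open whether an amine, a carboxylic acid or a longer chain there would move the number beyond the scatter.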